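Methyl for chloro on the benzyl of compound 3

A few compounds are considered here, and "the series" means these few. Any claim that something is new, unique, unknown or untested is made for them only; others in the source may bear on it.

Of the compounds shown here, three have been measured in a functional assay on DU-145 cells (Homo sapiens) for inhibition, read by trypan blue exclusion, with a stated time of 96 h; on this read-out lower numbers stand for stronger inhibition of growth and higher numbers for weaker inhibition of growth. Compound 1 `CSc1ccc(/C=C(\C(=O)c2ccc(Cl)cc2)S(=O)(=O)Cc2ccc(C)cc2)cc1` gives 10000 nM in this assay. Among the compounds with values here, compound 2 `Cc1ccc(CS(=O)(=O)/C(=C/c2ccc(N(C)C)cc2)C(=O)c2ccc(Cl)cc2)cc1` gives 50000 nM in this assay, and the one step that is measured, a 5.0-fold higher number from compound 1 to compound 2 (0.70 log units; beyond the scatter), is the only change whose size is known here. Compound 3 `Cc1ccsc1/C=C(\C(=O)c1ccc(Cl)cc1)S(=O)(=O)Cc1ccc(Cl)cc1` gives 25000 nM in this assay; of the three numbers it is the second highest, with compound 2 nearest and within the scatter of it, while compound 1 stands a lower number that is beyond the scatter.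

Compound 4 `Cc1ccc(CS(=O)(=O)/C(=C/c2sccc2C)C(=O)c2ccc(Cl)cc2)cc1` differs from compound 3 by one change: methyl in place of chloro on an aromatic carbon. Within the data shown here, the measured step from compound 1 to compound 2 concerns another group on another part of the shared core, so no measured step bears on this change, and nothing in the data lets a direction be read for it. The step from compound 3 to compound 4 in this assay is therefore expected to stay within the scatter, no change at the digits printed from compound 3 to compound 4 (within the scatter). On that basis compound 4 is estimated to give 25000 nM in this assay, in a range from 8000 nM to 70000 nM.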

Compound 4, concentration for 50% growth inhibition: 25000 nM
Compound 4: middle estimate and measured number agree at the digits printed; the range from low to high includes it.
By their numbers in this assay, from the lowest: compound 1; then compounds 3, 4 and 2 (each within the scatter of the next).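

In this assay, the change from 4-chlorobenzyl to 4-methylbenzyl, on an aromatic carbon para to a large group, gives no change at the digits printed from compound 3 to compound 4 (within the scatter) and so shows that, with the 3-methylthiophen-2-yl group in place, these two groups cannot be told apart at this position. Compound 4 also links the methylbenzyl series to the thiophene, and 3-methylthiophen-2-yl in place of 4-(dimethylamino)phenyl gives a 2.0-fold lower number from compound 2 to compound 4 (0.30 log units; within the scatter) while the same group in place of 4-(methylsulfanyl)phenyl gives a 2.5-fold higher number from compound 1 to compound 4 (0.40 log units; beyond the scatter) as a modest step beyond the scatter, so a change on the double-bonded chain carbon moves the number here while the benzyl change does not. No supporting measurement is available to explain either the flat benzyl step or the thiophene steps.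

Within the data shown here, the benzyl change is seen only with the 3-methylthiophen-2-yl group, so it remains open whether chloro and methyl would also match with 4-(methylsulfanyl)phenyl on the double-bonded chain carbon. As far as these compounds go, it also remains open what an amine, a carboxylic acid or a longer chain would do on the same aromatic carbon of the benzyl ring.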